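This account rests on a few compounds, and the source may have more. Where it says the series, first, only, none or still open, it means among the compounds named here.

Compound 1 `CCCc1nc(C)c2cnnc(O)n12` and compound 2 `CCCc1nc(C)c2cnnc(SC)n12` share one core and differ at a single place. In a functional assay for inhibition, with Homo sapiens as the target (a higher number here means a weaker inhibitor, a lower number a stronger inhibitor), compound 1 gives 56800 nM. For compound 2 this assay reports only a limit, > 48000 nM. The change between them is methylsulfanyl in place of hydroxy on an aromatic carbon, and the step is a step that the limit leaves unreadable from compound 1 to compound 2; its size cannot be read because of the limit of > 48000 nM in this assay, at which 2 of the 3 values shown sit.

Compound 3 `CCc1nc(C)c2c(-c3ccccc3)nnc(O)n12` is built on a different core; the difference between the two cores is not broken down here. In this assay compound 3 gives only a limit, > 48000 nM.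

Compound 4 `CCc1nc(C)c2c(-c3ccccc3)nnc(SC)n12` has not yet been measured in this assay. It differs from compound 3 by methylsulfanyl in place of hydroxy on an aromatic carbon. Within the data shown here, this is the same kind of change as the one from compound 1 to compound 2, though the surroundings are not identical: here the place is also para to a phenyl group (6 heavy atoms), which the first pair does not have.

What can be expected rests on little. Among the measured compounds shown here, compound 1 is weak, and the two other measured values in this assay are limits, so the only readable number lies close to the limit itself. The step from compound 3 to compound 4 is therefore expected to be a step that the limit leaves unreadable from compound 3 to compound 4, with no visible reason to expect a gain. Compound 4 is expected to give about 70000 nM in this assay, with a plausible range from 30000 nM to 200000 nM, and most likely the assay will again report only a limit for compound 4.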

Compound 4, half-maximal inhibitory concentration: > 48000 nM
Compound 4: a limit, no number; the forecaster's own chance of this, stated with the estimate: 85%; the middle value is on the limit's open side.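

In this assay compound 4 gives only a limit, > 48000 nM, so no step can be read from compound 3 to compound 4, and the cause is this: the limit of > 48000 nM in this assay, at which 3 of the 4 values shown sit.

The compounds shown leave open whether methylsulfanyl in place of hydroxy on an aromatic carbon changes inhibition at all, and how strong compound 2, compound 3 and compound 4 actually are.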